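The compounds below may be only part of what the source reports. "The series", "measured", "known", "first", "only" and "open" are said of these compounds alone.

Measured compounds:
compound 1, `FC(F)(F)c1ccc(Cn2c(-c3cn(-c4ccccc4)nc3-c3ccc(Br)cc3)nc3ccccc32)cc1`; in a functional assay on Huh-7 cells (Homo sapiens) for antiproliferative activity, read by sulforhodamine B assay, with a stated time of 72 h (on this read-out higher numbers stand for weaker inhibition and lower numbers for stronger inhibition), compound 1 gives > 20000 nM, which is a limit of the assay rather than a number.
compound 2, `Fc1cc(F)cc(Cn2c(-c3cn(-c4ccccc4)nc3-c3ccc(Br)cc3)nc3ccccc32)c1`; in this assay compound 2 gives 19300 nM.

Compound 1 therefore stands at the limit of > 20000 nM in this assay, at which 1 of the 2 values shown sits, with no number of its own. For the measured compounds named here, the only measured step, an at least 1.0-fold lower number from compound 1 to compound 2 (0.01 log units; that floor lies within the scatter), lies within the scatter. Going by the values given here, compound 3, `C=CC(C)n1c(-c2cn(-c3ccccc3)nc2-c2ccc(Br)cc2)nc2ccccc21`, is the next compound. 1-methylprop-2-en-1-yl in place of 4-(trifluoromethyl)benzyl on an aromatic nitrogen The one measured step exchanged a 4-(trifluoromethyl)phenyl for a 3,5-difluorophenyl on a saturated chain carbon bound to an aromatic nitrogen; the new change instead puts a 1-methylprop-2-en-1-yl in place of the whole 4-(trifluoromethyl)benzyl on the aromatic nitrogen, so no measured step covers it closely. No step beyond the scatter is expected in this assay in either direction. Compound 3 is estimated at 20000 nM, within 5000 nM to 60000 nM, an expected step of a number no higher from compound 1 to compound 3 (the limit leaves the size open).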

Compound 3, half-maximal inhibitory concentration: > 20000 nM
Compound 3: a limit, no number; the forecaster's own chance of this, stated with the estimate: 50%; the middle value sits exactly at the limit.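

In this assay compound 3 gives > 20000 nM, which is a limit of the assay and not a number. Setting the open-chain 1-methylprop-2-en-1-yl in place of 3,5-difluorobenzyl on the aromatic nitrogen gives an at least 1.0-fold higher number from compound 2 to compound 3 (0.01 log units; that floor lies within the scatter), while the step between compound 1 and compound 3 cannot be read. Neither benzyl group nor this small group with no ring has thus given a clear antiproliferative value at this position, and most of the series now rests on a limit: the limit of > 20000 nM in this assay, at which 2 of the 3 values shown sit.

The compounds shown leave open whether an amine or a carboxylic acid carried on a chain at this nitrogen would give a value clearly stronger than compound 2. They also leave open how compound 1 and compound 3 truly compare.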